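Notes on a fluorophenyl analogue of the whole-insect lead

The source may hold more compounds than are shown below. What is called first, only, known or untested is meant among the compounds shown, and "the series" means these compounds.

Measured so far:
- compound 1, `Cc1ccc(-c2nnc(COc3cnn(C(C)(C)C)c(=O)c3Cl)o2)cc1`, in a functional assay on the whole organism for inhibition, with Mythimna separata as the target, with a stated time of 5 days (on this read-out higher numbers stand for an effect only at larger amounts of compound and lower numbers for an effect already at smaller amounts), compound 1 gives 19.9 ug/mL.
- compound 2, `Cc1cc(C)cc(-c2nnc(COc3cnn(C(C)(C)C)c(=O)c3Cl)s2)c1`, in this assay compound 2 reaches only the limit of > 300 ug/mL, which is a limit of the assay and not a number.

Going by the values given here, compound 1 therefore holds the only real number in this assay; the other entry sits at the limit of > 300 ug/mL in this assay, at which 1 of the 2 values shown sits. Compound 2 differs from compound 1 in more than one place, so its limit says nothing about any single change.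

The next compound, compound 3, `CC(C)(C)n1ncc(OCc2nnc(-c3cccc(F)c3)o2)c(Cl)c1=O`, keeps the core of compound 1 and differs from it in one place: 3-fluorophenyl in place of 4-methylphenyl on an aromatic carbon. Among the compounds with values here, no measured pair isolates this change, so the expectation rests on compound 1 alone.

In this assay compound 3 is estimated at 30 ug/mL, with a range from 8 ug/mL to 120 ug/mL. The expected step of a 1.5-fold higher number from compound 1 to compound 3 (0.18 log units; within the scatter) is small and within the usual scatter; a larger loss, or a limit, cannot be ruled out.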

Compound 3, half-maximal effective concentration: 7.1 ug/mL
Estimate against measurement, compound 3: 4.2-fold (0.63 log units) above, outside the stated range (below it).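

In this assay, going by these compounds alone, replacing 4-methylphenyl with 3-fluorophenyl on the aromatic carbon next to the ring nitrogen and next to the ring oxygen gives a 2.8-fold lower number from compound 1 to compound 3 (0.45 log units; beyond the scatter), the first step that can be read at a single place. This position therefore responds to a change in its substituted phenyl group, and the 4-methylphenyl group of compound 1 is not required for an effect in this assay, since compound 3 gives 7.1 ug/mL without it. Nothing measured here accounts for the size or direction of this step.

The two phenyl groups differ both in the substituent and in where it stands on the ring, so this one step does not separate those two changes. On these data alone, whether the lower number holds with a methoxy or trifluoromethyl group on the phenyl ring, or with a pyridyl ring in its place, remains open.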